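This account rests on a few compounds, and the source may have more. Where it says the series, first, only, none or still open, it means among the compounds named here.

Measured in an ADME assay on K562 cells (Homo sapiens) for cytotoxicity, read by MTT assay, with a stated time of 24 h; on this read-out higher numbers stand for lower toxicity in this test and lower numbers for higher toxicity in this test:
- compound 1 `Clc1ccc(C(CCn2ccnc2)Oc2ccc(Cl)cc2Cl)cc1`: 68800 nM
- compound 2 `Clc1ccc(OC(CCn2ccnc2)c2ccccc2)cc1`: 256000 nM
- compound 3 `Clc1ccc(OC(CCn2ccnc2)c2ccc(Cl)cc2)cc1`: 265000 nM

Compound 1 gives the lowest number of the three, and both other compounds lie beyond the scatter from it. The next structure is compound 4 `CCc1ccc(OC(CCn2ccnc2)c2ccc(Cl)cc2)cc1`, which has not yet been measured in this assay. The change from compound 1 is 4-ethylphenyl in place of 2,4-dichlorophenyl on an oxygen on a saturated carbon.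

Going by the values given here, two measured steps bear on this. The closer one is a 3.9-fold higher number from compound 1 to compound 3 (0.59 log units; beyond the scatter), a modest step in which one chloro of the group that leaves gives way to hydrogen. The other is a 1.0-fold higher number from compound 2 to compound 3 (0.02 log units; within the scatter), so chloro in place of hydrogen on an aromatic carbon made no difference beyond the scatter in that pair. Among the compounds with values here, no measured step puts ethyl in place of chloro, so that part of the change remains open.

Within the data shown here, a modest rise from compound 1 is therefore expected, probably no larger than the one to compound 3. The expected step is a 2.6-fold higher number from compound 1 to compound 4 (0.42 log units; beyond the scatter). Compound 4 is estimated at 180000 nM, with an expected range of 75000 nM to 400000 nM.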

Compound 4, half-maximal cytotoxic concentration: 185000 nM
Estimate against measurement, compound 4: 1.0-fold (0.01 log units) below; low and high end bracket the measured number.
By their numbers in this assay, from the lowest: compound 1; then compounds 4, 2 and 3 (each within the scatter of the next).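

On the oxygen on a saturated carbon, 4-ethylphenyl in place of 2,4-dichlorophenyl gives a 2.7-fold higher number from compound 1 to compound 4 (0.43 log units; beyond the scatter) in this assay, a step that stays beyond the scatter even though the entering group carries no chlorine. Ethyl in place of chloro on an aromatic carbon, not covered by the earlier steps, gives a 1.4-fold lower number from compound 3 to compound 4 (0.16 log units; within the scatter), so this swap cannot be told from the scatter in this pair. No measurement at hand gives a reason for either step.

Still open, going by these compounds, is whether a longer chain, an amine or a carboxylic acid in place of ethyl would also stay within the scatter of compound 3. Going by these compounds alone, compound 1 is also the only compound with 2,4-dichlorophenyl, so it remains open whether its low number would hold on other versions of the core.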